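A cyclic peptide gains a lysine-like side chain

The source may hold more compounds than are shown below. What is called first, only, known or untested is meant among the compounds shown, and "the series" means these compounds.

Compound 1 `N=C(N)NCCC[C@@H]1NC(=O)CNC(=O)C[C@@H](C(=O)O)NC(=O)[C@@H](c2ccccc2)NC(=O)CNC1=O` is a cyclic peptide carrying a guanidine-bearing side chain, a phenyl group and a carboxy group. In an assay on a protein complex for binding affinity to integrin alpha-5/beta-1 (Homo sapiens), read by ELISA (on this read-out higher numbers stand for weaker inhibition and lower numbers for stronger inhibition), compound 1 gives 19 nM, the second highest number among three measured compounds. Compound 2 `CC(C)[C@H]1NC(=O)[C@H](CCCNC(=N)N)NC(=O)CNC(=O)C[C@@H](C(=O)O)NC(=O)[C@@H](c2ccccc2)NC1=O` gives 7.3 nM, and the step of a 2.6-fold lower number from compound 1 to compound 2 (0.42 log units; beyond the scatter) shows that adding a small branched group on a saturated ring carbon helps. Compound 3 `N=C(N)NCCC[C@@H]1NC(=O)CNC(=O)C[C@@H](C(=O)O)NC(=O)[C@@H](c2ccccc2)NC(=O)[C@@H]2CCCN2C1=O` gives 111 nM, a higher number than compound 1. Compound 4 `N=C(N)NCCC[C@@H]1NC(=O)CNC(=O)C[C@@H](C(=O)O)NC(=O)[C@@H](c2ccccc2)NC(=O)[C@H](CCCCN)NC1=O` differs from compound 1 by 4-aminobutyl in place of hydrogen on a saturated ring carbon. Going by the values given here, the only step that bears on this is the one from compound 1 to compound 2, a modest gain, so a similar modest step is expected for compound 4, a 1.6-fold lower number from compound 1 to compound 4 (0.20 log units; within the scatter), giving an estimated 12 nM with a range of 4 nM to 35 nM.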

Compound 4, half-maximal inhibitory concentration: 94 nM
Compound 4: middle estimate off by 7.8-fold (0.89 log units), on the low side; the measured number lies above the stated range.
By their numbers in this assay, from the lowest: compound 2; then compound 1; then compounds 4 and 3 (each within the scatter of the next).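

This ring carbon does not reward every added group: isopropyl gives a 2.6-fold lower number from compound 1 to compound 2 (0.42 log units; beyond the scatter), whereas 4-aminobutyl gives a 4.9-fold higher number from compound 1 to compound 4 (0.69 log units; beyond the scatter), so the direction of the step depends on the group that enters. The same carbon can therefore move the number either way. No measurement here explains why the two groups differ.

Going by these compounds, whether the weaker result follows the amine or the length of the chain remains open. A plain butyl group or a 3-carboxypropyl group on this carbon would help separate those two possibilities.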